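Triazole nitrogen substituent variation on a shared aminoquinoline core

The compounds below may be only part of what the source reports. "The series", "measured", "known", "first", "only" and "open" are said of these compounds alone.

Three compounds share a core and differ only in the group on an aromatic nitrogen of the triazole. In a functional assay on NCI-H460 cells (Homo sapiens) for antiproliferative activity, read by sulforhodamine B assay, with a stated time of 72 h (a higher number here means a weaker inhibitor, a lower number a stronger inhibitor), compound 1 `CN(CCNCc1cn(-c2ccc(Br)cc2)nn1)CCNc1ccnc2cc(Cl)ccc12` gives 15000 nM. Compound 2 `CN(CCNCc1cn(Cc2nc3ccccc3[nH]2)nn1)CCNc1ccnc2cc(Cl)ccc12` gives 120000 nM in this assay, and an 8.0-fold higher number from compound 1 to compound 2 (0.90 log units; beyond the scatter). Compound 3 `CN(CCNCc1cn(-c2ccnc3cc(Cl)ccc23)nn1)CCNc1ccnc2cc(Cl)ccc12` gives 16000 nM, so a 1.1-fold higher number from compound 1 to compound 3 (0.03 log units; within the scatter), while a 7.5-fold lower number from compound 2 to compound 3 (0.88 log units; beyond the scatter). On these numbers compound 3 stands second highest of the three, indistinguishable from compound 1 and clearly apart from compound 2.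

Compound 4 `CN(CCNCc1cn(CCC(=O)Nc2ccccn2)nn1)CCNc1ccnc2cc(Cl)ccc12` has not yet been measured in this assay. The change is 2-((pyridin-2-yl)carbamoyl)ethyl in place of 7-chloroquinolin-4-yl on an aromatic nitrogen. For the measured compounds named here, two steps bear on it: the aryl-to-aryl exchange a 1.1-fold higher number from compound 1 to compound 3 (0.03 log units; within the scatter) left the number unchanged, whereas the move to a methylene-linked heteroaryl, an 8.0-fold higher number from compound 1 to compound 2 (0.90 log units; beyond the scatter), raised it modestly. Compound 4 carries a chain-linked group rather than a directly attached aryl, so a modest rise from compound 3 is expected, a 2.8-fold higher number from compound 3 to compound 4 (0.45 log units; beyond the scatter). For compound 4 the estimated value is 45000 nM, with a range from 12000 nM to 160000 nM.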

Compound 4, half-maximal inhibitory concentration: > 200000 nM
Compound 4 gave a limit, no number (the forecaster's own chance of this, stated with the estimate: 10%); at least 4.4-fold (0.64 log units) between middle value and limit.
By their numbers in this assay, from the lowest: compounds 1 and 3 (each within the scatter of the next); then compound 2. At a limit, above all of these: compound 4.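

Compound 4 reads as a limit of the assay, not a number: the limit of > 200000 nM in this assay, at which 1 of the 4 values shown sits. This position is therefore not indifferent to its group: with the count of heavy atoms unchanged, 2-((pyridin-2-yl)carbamoyl)ethyl in place of 7-chloroquinolin-4-yl gives an at least 12-fold higher number from compound 3 to compound 4 (1.09 log units; beyond the scatter), and in place of 4-bromophenyl it gives an at least 13-fold higher number from compound 1 to compound 4 (1.12 log units; beyond the scatter). Against the methylene-linked benzimidazole the result is an at least 1.6-fold higher number from compound 2 to compound 4 (0.22 log units; that floor lies within the scatter), so those two chain-linked groups cannot be ordered, and both stand apart from the two directly attached aryl groups.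

On these data alone, it remains open whether the rise follows the chain, the amide or the pyridine ring. A plain ethyl chain, a carboxylic acid on the same chain, or a phenyl amide in place of the pyridin-2-yl amide would separate these.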